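A few compounds are considered here, and "the series" means these few. Any claim that something is new, unique, unknown or untested is made for them only; others in the source may bear on it.

Of the compounds shown here, two of a shared core have been tested in an assay on isolated protein for inhibition of ribosomal protein S6 kinase alpha-1 (Homo sapiens), read by mobility shift assay, tested at 30 uM; on this read-out lower numbers stand for less inhibition and higher numbers for more inhibition at the one concentration tested (going by the name of the read-out). Compound 1 `COc1cccc(-c2cc3c(c(N)nn3C)c(=O)[nH]2)c1` gives 22% in this assay. Compound 2 `CC(C)(C)c1cc2nn(-c3ccccc3)c(N)c2c(=O)[nH]1` gives 5% in this assay. On these two numbers compound 2 stands lowest, and its nearest neighbour, compound 1, sits a distance above it that lies beyond the usual scatter of repeated measurements. Within the data shown here, no single-point step between measured compounds has been recorded, so the account rests on these two values alone.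

Compound 3 `Nc1c2c(=O)[nH]c(-c3ccccn3)cc2nn1-c1ccccc1` has not yet been measured in this assay. It differs from compound 2 in one place: pyridin-2-yl in place of tert-butyl on an aromatic carbon. The step from compound 2 to compound 3 is expected to run upward, by a modest amount that may or may not clear the scatter, namely a number 10 percentage points higher from compound 2 to compound 3 (within the scatter); the only support for this direction is that compound 1, which carries an aromatic ring at the same place, gives 22%. Compound 3 is therefore estimated at 15% in this assay, with a range from 0% to 40%.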

Compound 3, a percentage reported as inhibition, at one concentration (the size of the read-out at that concentration, not a potency): 6%
The estimate for compound 3 lay 9 percentage points above the measured number; low and high end bracket the measured number.
By their numbers in this assay, from the lowest: compounds 2 and 3 (each within the scatter of the next); then compound 1.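

In this assay the step comes to a number 1 percentage points higher from compound 2 to compound 3 (within the scatter) when pyridin-2-yl replaces tert-butyl on this aromatic carbon next to the ring nitrogen. Among these compounds, as the only pair here that differs in one place, compound 2 and compound 3 show that putting a six-membered aromatic ring with one nitrogen and one hydrogen-bond acceptor where a ring-free group of four carbons stood does not separate the two compounds on this read-out. Nothing available explains this outcome.

Compound 3 differs from compound 1 in more than one place, and compound 1 gives 22% in this assay without showing which of those differences matters. As far as these compounds go, it remains open whether a different group on this aromatic carbon, such as an amine, a carboxylic acid or a longer alkyl chain, would give a number that clears the scatter, and whether pyridin-2-yl would behave the same way on a core carrying other groups elsewhere.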